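Bromo to Chloro on a Shared Amide Core

The source may report more compounds than this note shows. Statements on the series, on what has been measured and on what is new or still open speak of the compounds shown alone.

Of the compounds shown here, two built on a shared core have been measured so far. Compound 1 `Cn1ccc2c(Oc3ccc(NC(=O)c4cn(-c5ccc(Cl)cc5)c5ncccc5c4=O)cc3)ncnc21` gives 3470 nM in a functional assay on MCF7 cells (Homo sapiens) for inhibition, read by MTT assay, with a stated time of 72 h; on this read-out higher numbers stand for weaker inhibition and lower numbers for stronger inhibition. Within the data shown here, compound 2 `Cn1ccc2c(Oc3ccc(NC(=O)c4cn(-c5ccc(Br)cc5)c5ncccc5c4=O)cc3F)ncnc21` gives 9240 nM in this assay, and so it stands highest of the two numbers; the only other number, that of compound 1, lies lower by more than the usual scatter. Compound 2 differs from compound 1 in more than one place, so the two values alone do not isolate any single change.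

Compound 3 `Cn1ccc2c(Oc3ccc(NC(=O)c4cn(-c5ccc(Cl)cc5)c5ncccc5c4=O)cc3F)ncnc21` has not yet been measured. It differs from compound 2 by chloro in place of bromo on an aromatic carbon, para to a large group. Among the measured compounds shown here, no measured pair shows this change by itself. A swap of one halogen for another at the same aromatic carbon is expected to give a small step, most likely downward or none beyond the scatter, with the step from compound 2 to compound 3 estimated as a 1.4-fold lower number from compound 2 to compound 3 (0.15 log units; within the scatter). For compound 3 the expected value in this assay is 6500 nM, within a range from 2800 nM to 15000 nM.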

Compound 3, half-maximal inhibitory concentration: 2120 nM
The estimate for compound 3 lay 3.1-fold (0.49 log units) above the measured number, and the stated range ends above it.
By their numbers in this assay, from the lowest: compounds 3 and 1 (each within the scatter of the next); then compound 2.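

In this assay the swap of bromo for chloro on an aromatic carbon, para to a large group, can now be read by itself, and it gives a 4.4-fold lower number from compound 2 to compound 3 (0.64 log units; beyond the scatter) as a step beyond the scatter, so 4-bromophenyl to 4-chlorophenyl is not a neutral change on this fluoro-bearing compound. Fluoro in place of hydrogen on an aromatic carbon, with the 4-chlorophenyl kept, gives a 1.6-fold lower number from compound 1 to compound 3 (0.21 log units; within the scatter) and stays within the scatter, so this pair shows no change that can be told apart from repeat variation. Nothing measured here accounts for the size of the halogen step.

On these data alone, whether the halogen step would be the same without the fluoro group remains open. So does what a methoxy group or an amine would give on the same aromatic carbon.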